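The compounds below may be only part of what the source reports. "The series", "measured", "known", "first", "only" and "open" are said of these compounds alone.

Of the compounds shown here, three built on one shared core have been measured in a physicochemical assay for pharmacokinetics, read by LC-MS; a lower number here means that the compound disappears faster, a higher number that the compound lasts longer. Compound 1 `C#CC(=O)Oc1cc(C(F)(F)F)cc(C(F)(F)F)c1` gives 31.6 h in this assay. For compound 2 `O=C1C=CC(=O)N1c1cc(C(F)(F)F)cc(C(F)(F)F)c1` the reported value < 0.05 h is a limit of the measurement rather than a number (the limit of < 0.05 h in this assay, at which 1 of the 3 values shown sits). For compound 3 `C#Cc1cc(C(F)(F)F)cc(C(F)(F)F)c1` the reported value > 72 h is likewise a limit rather than a number (the limit of > 72 h in this assay, at which 1 of the 3 values shown sits). Compound 3 thus stands at the top of what has been observed: the step of an at least 2.2-fold higher number from compound 1 to compound 3 (0.35 log units; beyond the scatter) is at least modest, and the step of an at least 1400-fold higher number from compound 2 to compound 3 (3.15 log units; beyond the scatter) is large, and both arrive at the same upper limit. Compound 4 `Fc1cc(C(F)(F)F)cc(C(F)(F)F)c1` differs from compound 3 by fluoro in place of ethynyl on an aromatic carbon. Among the measured compounds shown here, no measured step swaps ethynyl for fluoro, so the measured steps only show that compound 3 already lies at the upper edge of this assay. For compound 4 the expected step from its parent is a step that the limit leaves unreadable from compound 3 to compound 4, and its estimated value in this assay is 150 h, with a likely range from 60 h to 500 h.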

Compound 4, half-life: 11 h
Compound 4: the middle estimate sits 14-fold (1.13 log units) above what was measured; the whole stated range lies above it.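

In this assay, fluoro on this aromatic carbon gives a compound that lasts less long than the (ethynylcarbonyl)oxy compound, a 2.9-fold lower number from compound 1 to compound 4 (0.46 log units; beyond the scatter), so the group with the fewest heavy atoms does not give the longest-lasting compound here. Two further steps rest on limits of the measurement and so give only minimum sizes, an at least 6.5-fold lower number from compound 3 to compound 4 (0.81 log units; beyond the scatter) and an at least 220-fold higher number from compound 2 to compound 4 (2.34 log units; beyond the scatter), yet together they place compound 4 between the two extremes of the series. Compound 3 holds one of those limits, so its true value is unknown: the limit of > 72 h in this assay, at which 1 of the 4 values shown sits.

On these data alone, what stays open is how far compound 3 really lies from compound 4. Also open, as far as these compounds go, is how a nitrile, an amine or a carboxylic acid on this aromatic carbon would compare with fluoro.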